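The compounds below may be only part of what the source reports. "The series", "measured", "known", "first", "only" and "open" are said of these compounds alone.

Measured compounds:
compound 1, `CC1(C)CC(NC(=O)Nc2ccccc2)c2cc(Cl)ccc2O1`, 7800 nM
compound 2, `COc1ccccc1NC(=O)NC1CC(C)(C)Oc2ccc(F)cc21`, > 10000 nM

In a functional assay (aorta) with Rattus norvegicus as the target (a higher number here means that more compound is needed for the effect, a lower number that less compound is needed), compound 1 gives 7800 nM. For compound 2 the result in this assay is > 10000 nM, which is a limit of the assay and not a number, so compound 2 is only known to sit at the limit of > 10000 nM in this assay, at which 1 of the 2 values shown sits. Going by the values given here, the two compounds differ in more than one place, so their values show only that compound 1 was measured as a number while compound 2 was not.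

Compound 3, `COc1ccccc1NC(=O)NC1CC(C)(C)Oc2ccc(Cl)cc21`, carries the change (chloro in place of fluoro on an aromatic carbon), chloro in place of fluoro on an aromatic carbon of the shared core, with the methoxyphenyl urea of compound 2 kept. Among the compounds with values here, no measured step tells how this exchange plays out in this assay. With compound 2 resting at a limit, the result for compound 3 is expected to stay close to that limit, and the step of an at least 1.1-fold lower number from compound 2 to compound 3 (0.04 log units; that floor lies within the scatter) is estimated to lie within the scatter, in no clear direction. The expected value for compound 3 in this assay is 9000 nM, with a range from 3000 nM to 30000 nM, and a real chance that only a limit is reported again.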

Compound 3, half-maximal effective concentration: > 10000 nM
Compound 3 gave a limit, no number (the forecaster's own chance of this, stated with the estimate: 55%); middle value at least 1.1-fold (0.04 log units) from the limit.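

With compound 3, the set gains its first readable step between compounds that differ in one place: methoxy in place of hydrogen on an aromatic carbon gives an at least 1.2-fold higher number from compound 1 to compound 3 (0.10 log units; that floor lies within the scatter) in this assay. This step is only a floor, so the compounds show no clear effect of the methoxy group on the result, in either direction. The exchange of fluoro for chloro on the aromatic carbon of the shared core cannot be read, and with the methoxy group in place neither of these two halogens brings the result to a number, since compound 2 and compound 3 both rest at a limit of the assay: the limit of > 10000 nM in this assay, at which 2 of the 3 values shown sit.

The compounds shown leave open how a group other than a halogen, such as an amine or a nitrile, would behave on this aromatic carbon in place of chloro. They also leave open whether a hydroxy group or a longer chain such as ethoxy in place of the methoxy group would return a number rather than a limit.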